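Carbamoyl in Place of the Sulfur-Bearing Group

This account rests on a few compounds, and the source may have more. Where it says the series, first, only, none or still open, it means among the compounds named here.

For the measured compounds named here, in a functional assay on L1210 cells (Mus musculus) for inhibition (on this read-out higher numbers stand for weaker inhibition and lower numbers for stronger inhibition), compound 2 `NC(=S)c1cn(COCc2ccccc2)c2ncnc(N)c12` gives 100000 nM, the higher of the two numbers measured so far. Compound 1 `NC(=O)c1cn(Cc2ccccc2)c2ncnc(N)c12` gives 16000 nM in this assay, a lower number that lies beyond the usual scatter. Compound 3 `NC(=O)c1cn(COCc2ccccc2)c2ncnc(N)c12` has not been measured; it differs from compound 2 by a group of 3 heavy atoms (1 carbon, 1 nitrogen, 1 oxygen; no ring) in place of a group of 3 heavy atoms (1 carbon, 1 nitrogen, 1 sulfur; no ring), on an aromatic carbon. Because compound 1 gives 16000 nM with the carbamoyl group in place, a move toward a lower number is expected. The change is expected to amount to a 5.0-fold lower number from compound 2 to compound 3 (0.70 log units; beyond the scatter). For compound 3 the estimated value is 20000 nM, with a likely range from 6000 nM to 70000 nM.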

Compound 3, half-maximal inhibitory concentration: 70000 nM
Estimate against measurement, compound 3: 3.5-fold (0.54 log units) below; the range from low to high includes it.
By their numbers in this assay, from the lowest: compound 1; then compounds 3 and 2 (each within the scatter of the next).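

Putting carbamoyl in place of the sulfur-bearing group on this aromatic carbon gives a 1.4-fold lower number from compound 2 to compound 3 (0.15 log units; within the scatter) in this assay, so exchanging sulfur for oxygen here does not shift the read-out beyond the scatter. Compound 3 carries carbamoyl and gives 70000 nM, whereas compound 1 gives 16000 nM, so carbamoyl alone does not reproduce the number of compound 1. Nothing measured here explains this result. As far as these compounds go, whether a nitrile or a carboxylic acid on this aromatic carbon would give a different number remains open.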